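Swapping a Methoxyphenyl Arm for a Furan Ring

This account rests on a few compounds, and the source may have more. Where it says the series, first, only, none or still open, it means among the compounds named here.

Three chalcone-type compounds have been tested for their ability to reduce swelling in an animal model, and a fourth awaits measurement. Compound 1 `COc1ccc(/C=C/C(=O)c2ccc(NC(=O)C(C)Br)cc2)cc1` and compound 2 `CC(Br)C(=O)Nc1ccc(C(=O)/C=C/c2ccco2)cc1` share a core carrying a brominated amide; compound 3 `COc1ccc(/C=C/C(=O)c2ccc(NC(=O)COCc3c(-c4ccccc4)no[n+]3[O-])cc2)cc1` and compound 4 `O=C(COCc1c(-c2ccccc2)no[n+]1[O-])Nc1ccc(C(=O)/C=C/c2ccco2)cc1` carry instead an oxadiazole-based side chain on the amide. In a functional assay on the whole organism (strain albino) for inhibition, with Rattus norvegicus as the target, read by paw edema, with stated times of 30 min and 2 h, at a dose of 100 mg/kg by the oral route (a lower number here means less inhibition, a higher number more inhibition at the dose given (going by the name of the read-out)), compound 1 gives 40%, and compound 2 gives 37%. The change from compound 1 to compound 2 is furan-2-yl in place of 4-methoxyphenyl on a double-bonded chain carbon bound to a double-bonded chain carbon, and it produced a number 3 percentage points lower from compound 1 to compound 2 (within the scatter). The difference between compound 1 and compound 3 lies in more than one place and is not broken down here; in this assay compound 3 gives 42%, a number that sits close to those of the other two.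

Compound 4 is reached from compound 3 by exactly the same change, (furan-2-yl in place of 4-methoxyphenyl on a double-bonded chain carbon bound to a double-bonded chain carbon). Among the measured compounds shown here, since the one measured example of this change, from compound 1 to compound 2, moved the read-out only a little in this assay, the expectation is that a similar small shift will appear here, an estimated a number 3 percentage points lower from compound 3 to compound 4 (within the scatter). Accordingly, compound 4 is expected to show about 39% in this assay, most likely somewhere between 29% and 49%, because compound 3 gives 42% and the step seen before was a number 3 percentage points lower from compound 1 to compound 2 (within the scatter).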

Compound 4, a percentage reported as inhibition, in the whole organism at one dose (the size of the read-out at that dose, not a potency): 45%
Compound 4: the middle estimate sits 6 percentage points below what was measured, within the range that was stated.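

On the core of compound 3, furan-2-yl in place of 4-methoxyphenyl on a double-bonded chain carbon bound to a double-bonded chain carbon gave, in this assay, a number 3 percentage points higher from compound 3 to compound 4 (within the scatter). Set beside the earlier example of the same change, the two cores cannot be told apart in how they respond, and on both the change stays small enough to be lost in the ordinary spread of such measurements: the same change on two cores in this assay, a number 3 percentage points lower (within the scatter) from compound 1 to compound 2 and a number 3 percentage points higher (within the scatter) from compound 3 to compound 4, 6 percentage points apart, within the scatter of two such steps. This supports only a modest statement, that in these two pairs the swap made no clear difference on either core, and it does not show that the change truly raises or lowers inhibition, since the two steps point in opposite directions without either one standing clear of the scatter.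

The compounds shown also leave open whether a group of a different kind on that chain carbon, such as a carboxylic acid or an amine, would move the read-out by a clear margin. As far as these compounds go, whether a step that stands clear of the scatter on one core would carry over to the other also remains open, since neither pair here offers such a step to follow.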